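Expected Cytotoxicity After Swapping an Aryl Tail for Piperidine

This account rests on a few compounds, and the source may have more. Where it says the series, first, only, none or still open, it means among the compounds named here.

Compound 1 `CN1Cc2ccc(OCc3ccc(-c4ccccc4)cc3)cc2[C@@H](O)C1` gives 23000 nM in an ADME assay on Vero cells (Chlorocebus sabaeus) for cytotoxicity, read by sulforhodamine B assay, with a stated time of 72 h; a higher number here means a weaker inhibitor, a lower number a stronger inhibitor.
Compound 2 `CN1Cc2ccc(OCc3ccc([N+](=O)[O-])cc3)cc2[C@@H](O)C1` gives > 50000 nM in this assay, which is a limit of the assay.
Compound 3 `Cc1cccc(COc2ccc3c(c2)[C@@H](O)CN(C)C3)c1` gives > 50000 nM in this assay, likewise a limit of the assay.

Compound 3 thus stands at the limit of > 50000 nM in this assay, at which 2 of the 3 values shown sit, and only a limit is known for it, whereas compound 1 gives a measured number. Among the compounds with values here, the one step measured in the same region of the molecule, an at least 2.1-fold higher number from compound 1 to compound 2 (0.33 log units; beyond the scatter), ran from a number up to that limit. Compound 4 `CN1Cc2ccc(OCC3CCNCC3)cc2[C@@H](O)C1` differs from compound 3 by piperidin-4-yl in place of 3-methylphenyl on a saturated chain carbon bound to an oxygen on an aromatic ring. The measured step exchanged one substituent on the aromatic ring for another; the present change removes that ring altogether, so the measured step bears on it only loosely. Within the data shown here, with compound 3 already at a limit and the one comparable step having moved toward that limit, no step beyond the scatter is expected here. The expected step is a step that the limit leaves unreadable from compound 3 to compound 4. The value of compound 4 in this assay is estimated at 60000 nM, with a range from 25000 nM to 150000 nM, and it will most likely again be reported only as a limit.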

Compound 4, half-maximal inhibitory concentration: > 100000 nM
Compound 4 was reported as a limit (the forecaster's own chance of this, stated with the estimate: 75%); middle value at least 1.6-fold (0.22 log units) away from the limit.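

Compound 3 and compound 4 are both reported only as limits in this assay, and no step can be read between them. The compounds shown leave open whether piperidin-4-yl in place of 3-methylphenyl changes the number at all.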